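1,3-Thiazol-2-yl for 1,3-Oxazol-2-yl on Two Cores

The compounds below may be only part of what the source reports. "The series", "measured", "known", "first", "only" and "open" are said of these compounds alone.

Measured so far:
compound 1, `O=C(O)c1cc(-c2ncco2)ccc1O`: 100 mg/kg
compound 2, `O=C(O)c1cc(-c2nccs2)ccc1O`: > 250 mg/kg
compound 3, `O=C(O)c1ccc(-c2ncco2)cc1O`: > 250 mg/kg

All three were tested in a functional assay on the whole organism for inhibition, with Rattus norvegicus as the target, read by paw edema; on this read-out higher numbers stand for an effect only at larger amounts of compound and lower numbers for an effect already at smaller amounts. Compound 1 gives 100 mg/kg. Compound 2 reaches only a limit of the assay, > 250 mg/kg. The change between them is 1,3-thiazol-2-yl in place of 1,3-oxazol-2-yl on an aromatic carbon, and it made a step of an at least 2.5-fold higher number from compound 1 to compound 2 (0.39 log units; beyond the scatter).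

Compound 3 has the same atoms as compound 1 joined differently; how the two cores differ is not broken down here. Compound 3 also gives only a limit, > 250 mg/kg.

Compound 4, `O=C(O)c1ccc(-c2nccs2)cc1O`, is not yet measured. It arises from compound 3 by 1,3-thiazol-2-yl in place of 1,3-oxazol-2-yl on an aromatic carbon. This is the same kind of change as before, but around a different place: in compound 1 the group sits meta to a carboxy group and para to a hydroxy group, in compound 3 meta to a hydroxy group and para to a carboxy group.

Compound 3 already sits at the limit of > 250 mg/kg in this assay, at which 2 of the 3 values shown sit, and the earlier change moved the number upward. Compound 4 is therefore expected at 400 mg/kg, most likely again as a limit. The expected step is a step that the limit leaves unreadable from compound 3 to compound 4.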

Compound 4, dose for half-maximal effect: 110 mg/kg
Beside the measured number, compound 4's estimate is 3.6-fold (0.56 log units) above it, outside the stated range (below it).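

In this assay, putting 1,3-thiazol-2-yl in place of 1,3-oxazol-2-yl gave an at least 2.2-fold lower number from compound 3 to compound 4 (0.35 log units; beyond the scatter), so on this core the number moved the opposite way from the earlier core. The change therefore did not carry over from one core to the other, not even in its direction: the same change on two cores in this assay, an at least 2.5-fold higher number (0.39 log units; beyond the scatter) from compound 1 to compound 2 and an at least 2.2-fold lower number (0.35 log units; beyond the scatter) from compound 3 to compound 4, at least 5.6-fold (0.75 log units) apart, beyond the scatter of two such steps. This does not show the true size of either step, since each one has a limit at one end, and two cores give no rule for a further core: the limit of > 250 mg/kg in this assay, at which 2 of the 4 values shown sit.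

The compounds shown leave open how a different group at the same place, such as a phenyl ring or an amide, would compare on either core. They also leave open whether the opposite directions would persist if the carboxy group were replaced by a methyl ester or a tetrazole.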